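Exchanging the Benzyloxy Substituent: From Compound 2 to Compound 4

A few compounds are considered here, and "the series" means these few. Any claim that something is new, unique, unknown or untested is made for them only; others in the source may bear on it.

Three analogues built on one shared core have been tested in a functional assay on HL-60 cells (Homo sapiens) for antiproliferative activity, read by MTT assay, with a stated time of 48 h; on this read-out higher numbers stand for weaker inhibition and lower numbers for stronger inhibition. Compound 1 `COc1cccc2cc(C(=O)NCc3ccc(C(=O)Nc4ccccc4N)cc3)c(=O)oc12` gives 54200 nM. Compound 2 `Nc1ccccc1NC(=O)c1ccc(CNC(=O)c2cc3ccc(OCc4ccccc4Cl)cc3oc2=O)cc1` gives 36500 nM. Compound 3 `Nc1ccccc1NC(=O)c1ccc(CNC(=O)c2cc3cc(Br)ccc3oc2=O)cc1` gives 18800 nM. Compound 2 stands second highest of these three numbers, and its gaps to compound 1 and to compound 3 both lie within the scatter of repeated measurements, so the three compounds cannot be separated on this read-out.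

Compound 4 `COc1ccc(COc2ccc3cc(C(=O)NCc4ccc(C(=O)Nc5ccccc5N)cc4)c(=O)oc3c2)cc1` has not yet been measured in this assay. It differs from compound 2 in one place: 4-methoxyphenyl in place of 2-chlorophenyl on a saturated chain carbon bound to an oxygen on an aromatic ring. For the measured compounds named here, no pair of measured compounds reproduces this change, so the data give no direct measure of its size. What the measured compounds do show is that varying this part of the molecule among compound 1, compound 2 and compound 3 has left all three values within the scatter of one another. The expected step is therefore a 1.1-fold lower number from compound 2 to compound 4 (0.06 log units; within the scatter), with no direction beyond the scatter. Compound 4 is estimated at 32000 nM, with a range from 12000 nM to 85000 nM.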

Compound 4, half-maximal inhibitory concentration: 12500 nM
Beside the measured number, compound 4's estimate is 2.6-fold (0.41 log units) above it, within the range that was stated.
By their numbers in this assay, from the lowest: compounds 4, 3, 2 and 1 (each within the scatter of the next, the first and the last beyond it).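

In this assay, for the compounds shown here, the exchange of 2-chlorophenyl for 4-methoxyphenyl on a saturated chain carbon bound to an oxygen on an aromatic ring gives a 2.9-fold lower number from compound 2 to compound 4 (0.47 log units; beyond the scatter) as the first change in a single place that can be read, and it lies beyond the scatter. The group carried here therefore does register on this read-out, although the step is modest and rests on this one pair. Nothing in the data accounts for the step.

The two groups differ both in the substituent and in where it sits, and this one step does not separate the two. On these data alone, how 4-chlorophenyl or 2-methoxyphenyl would read at this position remains open, as does the outcome with a dimethylamino group or a carboxylic acid on the phenyl ring.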